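Chloro on the Phenyl Ring: Expected Cytotoxicity Step

The source may report more compounds than this note shows. Statements on the series, on what has been measured and on what is new or still open speak of the compounds shown alone.

compound 1, `CCOC(=O)c1c(-c2c(Cl)c3ccccc3oc2=O)nn(-c2ccccc2)c1C(=O)OCC`: 48000 nM
compound 2, `CCOC(=O)c1c(-c2c(Cl)c3cc(C)ccc3oc2=O)nn(-c2ccccc2)c1C(=O)OCC`: 50000 nM

Of the compounds shown here, two have been measured in a functional assay on DU-145 cells (Homo sapiens) for cytotoxicity, read by MTT assay, with a stated time of 48 h; on this read-out lower numbers stand for stronger inhibition and higher numbers for weaker inhibition. Compound 1 `CCOC(=O)c1c(-c2c(Cl)c3ccccc3oc2=O)nn(-c2ccccc2)c1C(=O)OCC` gives 48000 nM in this assay, and compound 2 `CCOC(=O)c1c(-c2c(Cl)c3cc(C)ccc3oc2=O)nn(-c2ccccc2)c1C(=O)OCC` gives 50000 nM. The step of a 1.0-fold higher number from compound 1 to compound 2 (0.02 log units; within the scatter) lies within the scatter, so the two values cannot be told apart; on the numbers shown, compound 2 stands alongside compound 1, separated from it only by that step.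

Compound 3 `CCOC(=O)c1c(-c2c(Cl)c3cc(C)ccc3oc2=O)nn(-c2cccc(Cl)c2)c1C(=O)OCC` is not yet measured. It differs from compound 2 by chloro in place of hydrogen on an aromatic carbon. Within the data shown here, no measured step touches the phenyl ring on the nitrogen; the only step available, a 1.0-fold higher number from compound 1 to compound 2 (0.02 log units; within the scatter), concerns a methyl on a different ring and shows a small aromatic substitution that left the number unchanged within the scatter. That step bears on the new change only loosely. With nothing pointing either way, the expected step of a 1.3-fold lower number from compound 2 to compound 3 (0.10 log units; within the scatter) is none beyond the scatter. Compound 3 is therefore expected to give about 40000 nM in this assay, within a range from 15000 nM to 100000 nM.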

Compound 3, half-maximal inhibitory concentration: 156000 nM
Beside the measured number, compound 3's estimate is 3.9-fold (0.59 log units) below it, and the stated range ends below it.
By their numbers in this assay, from the lowest: compounds 1 and 2 (each within the scatter of the next); then compound 3.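

In this assay, the change from phenyl to 3-chlorophenyl gives a 3.1-fold higher number from compound 2 to compound 3 (0.49 log units; beyond the scatter), a modest step toward weaker inhibition and the only step among these compounds that lies beyond the scatter. The earlier step, a 1.0-fold higher number from compound 1 to compound 2 (0.02 log units; within the scatter), stayed within the scatter, so only with this chloro do the compounds show that a single small aromatic substitution on the shared core can move the number, and that at this place, adding chloro to the phenyl of compound 2 goes against inhibition. Nothing available bears on why the number moved in this direction.

The compounds shown leave open whether this loss belongs to chloro itself or would also follow from another group at the same place, such as a methoxy group, an amine or a carboxylic acid. They also leave open whether the same phenyl to 3-chlorophenyl change would give a step of similar size on the core of compound 1, which lacks the methyl of compound 2.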